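The source may hold more compounds than are shown below. What is called first, only, known or untested is meant among the compounds shown, and "the series" means these compounds.

Compound 3 `Cn1cc(C2=C(c3nn(CCCCn4ccnc4)c4ncccc34)C(=O)NC2=O)c2ccccc21` sits alongside compound 2 `Cn1cc(C2=C(c3nn(CCCn4ccnc4)c4ncccc34)C(=O)N(c3ccccc3)C2=O)c2ccccc21` in a functional assay on A549 cells (Homo sapiens) for antiproliferative activity, read by MTT assay, with a stated time of 48 h; on this read-out higher numbers stand for weaker inhibition and lower numbers for stronger inhibition: compound 3 gives 2380 nM, and compound 2 gives 1560 nM, the two lying within the scatter of each other. Compound 1 `CN(C)CCCn1nc(C2=C(c3cn(C)c4ccccc34)C(=O)NC2=O)c2cccnc21` reaches only the limit > 100000 nM in this assay. Among the measured compounds shown here, the one single-point step measured so far runs from compound 1 to compound 3, an at least 42-fold lower number from compound 1 to compound 3 (1.62 log units; beyond the scatter), resting on (the limit of > 100000 nM in this assay, at which 1 of the 3 values shown sits).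

Compound 4 `Cn1cc(C2=C(c3nn(CCCCn4ccnc4)c4ncccc34)C(=O)N(c3ccccc3)C2=O)c2ccccc21` carries phenyl in place of hydrogen on an amide-type nitrogen in a ring. For the measured compounds named here, no measured step changes this amide-type nitrogen alone; compound 2 also bears the phenyl there but with a shorter chain, so its value can only be read as a hint. For compound 4 a step within the scatter is expected, a 1.2-fold lower number from compound 3 to compound 4 (0.08 log units; within the scatter), in this assay. Compound 4 is therefore estimated at 2000 nM, between 800 nM and 5000 nM.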

Compound 4, half-maximal inhibitory concentration: 21700 nM
Compound 4: the middle estimate sits 11-fold (1.04 log units) below what was measured; the whole stated range lies below it.
By their numbers in this assay, from the lowest: compounds 2 and 3 (each within the scatter of the next); then compound 4. At a limit, above all of these: compound 1.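

Phenyl in place of hydrogen on the amide-type nitrogen in a ring is not neutral on this chain, with a 9.1-fold higher number from compound 3 to compound 4 (0.96 log units; beyond the scatter). With phenyl held in place, the chain matters too, with a 14-fold higher number from compound 2 to compound 4 (1.14 log units; beyond the scatter), so the closeness of compound 2 and compound 3 does not mean that either place is indifferent. Nothing measured here gives a cause for either step. Open, as far as these compounds go, is whether a methyl or benzyl group on that nitrogen acts like phenyl, and whether a longer chain moves the number further.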